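Estimating a tert-butyl swap on compound 1

The source may hold more compounds than are shown below. What is called first, only, known or untested is meant among the compounds shown, and "the series" means these compounds.

Values measured in a functional assay on a cell-free system (plasma, Homo sapiens), with a stated time of 3 min (on this read-out lower numbers stand for stronger inhibition and higher numbers for weaker inhibition), so far:
- compound 1 `CC1(C[C@@H](O)C(=O)N2N=CC[C@H]2C(=O)NCc2cc(Cl)ccc2-n2cnnn2)CC1` gives 730 nM
- compound 2 `O=C([C@H](O)c1ccccc1)N1CC[C@@H]2C[C@@]21C(=O)NCc1cc(Cl)ccc1-n1cnnn1` gives 1100 nM
- compound 3 `O=C(NCc1cc(Cl)ccc1-n1cnnn1)[C@@H]1CCNN1C(=O)[C@H](O)c1ccccc1` gives 930 nM

Compound 1 stands within the usual scatter of both compound 2 and compound 3, so these three values cannot be told apart. Compound 4 (`CC(C)(C)[C@@H](O)C(=O)N1N=CC[C@H]1C(=O)NCc1cc(Cl)ccc1-n1cnnn1`) has not yet been measured. It carries tert-butyl in place of (1-methylcyclopropyl)methyl on a saturated chain carbon bound to a carbonyl carbon and an oxygen on a saturated carbon and keeps the core of compound 1. Within the data shown here, no measured pair isolates a comparable change, so the expectation in this assay rests on compound 1 at 730 nM as its anchor. The estimated step is a 1.0-fold higher number from compound 1 to compound 4 (0.01 log units; within the scatter) in this reading. For compound 4 the expected value is 750 nM with an estimated range of 300 nM to 1900 nM for a single measurement.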

Compound 4, half-maximal inhibitory concentration: 1400 nM
Estimate against measurement, compound 4: 1.9-fold (0.27 log units) below, and the stated range covers the measured number.
By their numbers in this assay, from the lowest: compounds 1, 3, 2 and 4 (each within the scatter of the next).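

Tert-butyl in place of (1-methylcyclopropyl)methyl on a saturated chain carbon bound to a carbonyl carbon and an oxygen on a saturated carbon gives, in this assay, a 1.9-fold higher number from compound 1 to compound 4 (0.28 log units; within the scatter). Among these compounds, this is the first comparison at this position that differs in one place only, and losing the three-membered ring leaves the result within the usual scatter. No supporting evidence bears on this result. The compounds shown leave open how an amine or a carboxylic acid would read at this position. This single pair, with both groups made of carbon only, cannot settle that.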